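The compounds below may be only part of what the source reports. "The series", "measured", "known", "first", "only" and "open" are said of these compounds alone.

Compound 1, `CCCSc1nnc(COc2cc(C)c3c(C)cc(=O)oc3c2)o1`, in a functional assay on MCF7 cells (Homo sapiens) for antiproliferative activity, read by MTT assay, with a stated time of 24 h (a higher number here means a weaker inhibitor, a lower number a stronger inhibitor), gives only the limit of the assay, > 100000 nM.
Compound 2, `CCCCSc1nnc(COc2cc(C)c3c(C)cc(=O)oc3c2)o1`, in this assay gives only a limit as well, > 100000 nM.
Compound 3, `CCCCCCS(=O)(=O)c1nnc(COc2cc(C)c3c(C)cc(=O)oc3c2)o1`, in this assay likewise gives only a limit, > 100000 nM.

Compound 3 thus stands where the other two measured compounds stand: at the limit of the assay, on no readable scale, as the limit of > 100000 nM in this assay, at which 3 of the 3 values shown sit, shows. The steps among the measured compounds say nothing about size: a step that the two limits leave unreadable from compound 1 to compound 2, a step that the two limits leave unreadable from compound 1 to compound 3 and a step that the two limits leave unreadable from compound 2 to compound 3 are all hidden behind the limit, so neither the lengthening of the chain nor the move from a sulfanyl to a sulfonyl link has a measured size here.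

Compound 4, `Cc1cc(OCc2nnc(S(=O)(=O)Cc3ccccc3)o2)cc2oc(=O)cc(C)c12`, differs from compound 3 by phenyl in place of pentyl on a saturated chain carbon bound to a sulfonyl sulfur. For the measured compounds named here, none of the measured steps covers this change, and none of them was readable, so no direction and no size can be taken from them. With every shown value sitting at the limit, the expected step in a step that the limit leaves unreadable from compound 3 to compound 4 is one of no readable size. Compound 4 is therefore estimated at 150000 nM, with a range from 30000 nM to 1000000 nM, and is most likely to be returned again as a limit rather than a number.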

Compound 4, half-maximal inhibitory concentration: 38600 nM
Compound 4: middle estimate off by 3.9-fold (0.59 log units), on the high side; measured number inside the range.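

In this assay, for the compounds shown here, phenyl in place of pentyl on a saturated chain carbon bound to a sulfonyl sulfur gives the one step at this position that can be sized against a sulfonyl partner, an at least 2.5-fold lower number from compound 3 to compound 4 (0.41 log units; beyond the scatter), and it shows that the group at the end of the sulfonyl chain can move the result where the earlier compounds showed no movement at all. The comparisons with the two sulfanyl compounds read alike: benzylsulfonyl in place of butylsulfanyl gives an at least 2.5-fold lower number from compound 2 to compound 4 (0.41 log units; beyond the scatter), and benzylsulfonyl in place of propylsulfanyl gives an at least 2.5-fold lower number from compound 1 to compound 4 (0.41 log units; beyond the scatter). All three steps are lower bounds, and compound 4 alone carries a number in this set: the limit of > 100000 nM in this assay, at which 3 of the 4 values shown sit.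

The steps among compound 1, compound 2 and compound 3 cannot be read, so the sulfonyl link and the chain length still have no measured effect of their own, and the shown compounds do not tell whether the phenyl ring needs the sulfonyl link. Also open, as far as these compounds go, is what a benzylsulfanyl group would give at this place, or a benzylsulfonyl group whose phenyl ring carries an amine or a carboxylic acid.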